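From Methoxy to Nitro: Expecting Little Change

The source may hold more compounds than are shown below. What is called first, only, known or untested is meant among the compounds shown, and "the series" means these compounds.

In an ADME assay on HaCaT cells (Homo sapiens) for inhibition, read by sulforhodamine B assay, with a stated time of 48 h (a higher number here means a weaker inhibitor of growth, a lower number a stronger inhibitor of growth), compound 1 (`CCOC(=O)c1nn(-c2ccc(Cl)cc2)c(-c2ccc([N+](=O)[O-])cc2)c1CNC(C)(C)C`) gives 10300 nM; 145000 nM (2 entries). That spread, seen in the several entries of compound 1 in this assay, 10300 nM; 145000 nM (2 entries), is a warning that any single number in this kind of test deserves caution. Compound 2 (`COc1ccc(-c2c(CNC(C)(C)C)c(C(=O)O)nn2-c2ccc(Cl)cc2)cc1`) gives 121000 nM, the only single number shown here, and no step between two measured compounds is available as a guide.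

Compound 3 (`CC(C)(C)NCc1c(C(=O)O)nn(-c2ccc(Cl)cc2)c1-c1ccc([N+](=O)[O-])cc1`) comes from compound 2 through one change: nitro in place of methoxy on an aromatic carbon. In words, nitro takes the place of methoxy on an aromatic carbon, para to a large group.

With only compound 2 at 121000 nM to lean on, no step beyond the usual scatter is expected in this assay, in either direction. The expected move a 1.2-fold lower number from compound 2 to compound 3 (0.08 log units; within the scatter) is therefore small. The estimate for compound 3 is 100000 nM, with an expected range from 30000 nM to 300000 nM.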

Compound 3, concentration for 50% growth inhibition: > 583000 nM
Compound 3: a limit, no number; the forecaster's own chance of this, stated with the estimate: 10%; middle value at least 5.8-fold (0.76 log units) from the limit.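

Going by these compounds alone, at this position, nitro in place of methoxy is not the neutral swap it seemed: in this assay, the change gives an at least 4.8-fold higher number from compound 2 to compound 3 (0.68 log units; beyond the scatter), the first step between two measured compounds here, and it points towards a weaker inhibitor of growth. Compound 3 is recorded as a limit, > 583000 nM, and not as a number. Even so, the step should be read with care, because single readings in this test can differ widely: the several entries of compound 1 in this assay, 10300 nM; 145000 nM (2 entries)

The compounds shown leave open where an amine or a hydroxyl group in the same place on the ring would fall relative to compound 2 and compound 3. They also leave open whether the change from 4-methoxyphenyl to 4-nitrophenyl would give a similar step if an amide replaced the carboxylic acid of the shared core.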